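This account rests on a few compounds, and the source may have more. Where it says the series, first, only, none or still open, it means among the compounds named here.

Compound 1 `O=C1CSC(c2c(Cl)cccc2Cl)N1CCN1CCCCC1`: 11%
Compound 2 `O=C1CSC(c2cccc(Cl)c2)N1CCN1CCCCC1`: 31%

In an ADME assay on Vero cells (Chlorocebus sabaeus) for cytotoxicity, read by neutral red uptake, tested at 787 ug/mL (on this read-out higher numbers stand for a weaker effect at the one concentration tested and lower numbers for a stronger effect), compound 1 gives 11%, and compound 2 gives 31%. Going by the values given here, compound 2 stands highest of the two numbers on hand; the only neighbour, compound 1, lies lower by a gap that goes beyond the usual scatter of this kind of measurement, so compound 2 is the weaker of the two on this read-out. Whether that gap comes from its two chlorines or from where they sit is not settled by two compounds.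

Compound 3 `O=C1CSC(c2ccc(F)cc2)N1CCN1CCCCC1` has not yet been measured in this assay. It differs from compound 2 in one place: 4-fluorophenyl in place of 3-chlorophenyl on a saturated ring carbon. Among the compounds with values here, no pair of measured compounds carries this change, so there is no step on record to lean on. With only the number of compound 2 as a starting point, and with no evidence either way, the account expects a step from compound 2 to compound 3 of a number 3 percentage points lower from compound 2 to compound 3 (within the scatter), that is, no change beyond the scatter in either direction. Compound 3 is accordingly expected to give about 28% in this assay, within a range from 10% to 50%.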

Compound 3, a percentage reported as activity, at one concentration (the size of the read-out at that concentration, not a potency): 17%
Beside the measured number, compound 3's estimate is 11 percentage points above it; the measured number falls inside the stated range.
By their numbers in this assay, from the lowest: compounds 1 and 3 (each within the scatter of the next); then compound 2.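

In this assay, the aryl group on the saturated ring carbon now has a measured step, since 4-fluorophenyl in place of 3-chlorophenyl gives a number 14 percentage points lower from compound 2 to compound 3 (beyond the scatter). The read-out at this position therefore responds to an exchange of one halogenated phenyl for another, even though the two groups match in heavy-atom count and carry no hydrogen-bond donors or acceptors, and a second chlorine is not needed to reach the level of compound 1, as compound 3, with a single fluorine, lies within the scatter of it. Nothing on hand offers a measured reason for this step.

The change alters the halogen and its place on the phenyl ring together, so the compounds shown cannot say which of the two carries the step; 4-chlorophenyl and 3-fluorophenyl would each alter only one of them. Plain phenyl at the same carbon would also give a reference that none of these halogenated compounds provides, leaving open whether any halogen matters here at all.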